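This account rests on a few compounds, and the source may have more. Where it says the series, first, only, none or still open, it means among the compounds named here.

Of the compounds shown here, two built on one shared core have so far been tested in a functional assay on DU-145 cells (Homo sapiens) for cytotoxicity, read by sulforhodamine B assay, with a stated time of 48 h; on this read-out higher numbers stand for lower toxicity in this test and lower numbers for higher toxicity in this test. Compound 1 (`N#Cc1ccc(Nc2nc(Oc3ccnc4ccccc34)nc(N3CCN(c4cccc(C(F)(F)F)c4)CC3)n2)cc1C(F)(F)F`) gives only a limit of the test, > 100000 nM. Compound 2 (`N#Cc1ccc(Nc2nc(Oc3ccnc4ccccc34)nc(N3CCN(Cc4ccccc4)CC3)n2)cc1C(F)(F)F`) also gives only a limit, > 100000 nM. Going by the values given here, both compounds sit at the limit of > 100000 nM in this assay, at which 2 of the 2 values shown sit, so the single measured step, a step that the two limits leave unreadable from compound 1 to compound 2, cannot be read in size or direction. Compound 3 (`N#Cc1ccc(Nc2nc(Oc3ccnc4ccccc34)nc(N3CCN(c4ccccc4)CC3)n2)cc1C(F)(F)F`) differs from compound 2 in one place: phenyl in place of benzyl on an amine nitrogen in a ring. Among the compounds with values here, no measured step bears directly on this change, and the one step that exists is unreadable, so nothing points away from the limit. Compound 3 is therefore expected to remain near that limit. The expected step is a step that the limit leaves unreadable from compound 2 to compound 3, that is, nothing beyond the scatter. The estimate for compound 3 is 150000 nM, with a range from 40000 nM to 600000 nM.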

Compound 3, concentration lethal to 50% of the cells: > 100000 nM
Compound 3 gave a limit, no number; the forecaster's own chance of this, stated with the estimate: 85%; the middle value does not contradict the limit.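

Compound 3 also gives only a limit, so no step among compound 1, compound 2 and compound 3 can be read in size or direction: the limit of > 100000 nM in this assay, at which 3 of the 3 values shown sit.

These compounds leave open how far each lies beyond that limit, and whether changing the group on the amine nitrogen in the ring alters toxicity at all.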